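One Amino Group Added on Two Related Cores

This account rests on a few compounds, and the source may have more. Where it says the series, first, only, none or still open, it means among the compounds named here.

Measured so far:
compound 1 `ClCc1ccc(Cn2cnc3c(Cl)ncnc32)cc1`: 25100 nM
compound 2 `Nc1nc(Cl)c2ncn(Cc3ccc(CCl)cc3)c2n1`: 56200 nM
compound 3 `ClCc1ccccc1Cn1cnc2c(Cl)ncnc21`: 7080 nM

In a functional assay on HCT-116 cells (Homo sapiens) for cytotoxicity, read by sulforhodamine B assay, with a stated time of 48 h (a higher number here means that more compound is tolerated, a lower number that less compound is tolerated), compound 1 gives 25100 nM, compound 2 gives 56200 nM and compound 3 gives 7080 nM. Compound 2 differs from compound 1 by amino in place of hydrogen on an aromatic carbon, a change that produced a 2.2-fold higher number from compound 1 to compound 2 (0.35 log units; beyond the scatter). Compound 4 `Nc1nc(Cl)c2ncn(Cc3ccccc3CCl)c2n1` has not yet been measured; it differs from compound 3 by amino in place of hydrogen on an aromatic carbon, the same change at the same place. The difference between the cores of compound 1 and compound 3 is not broken down here. In this assay compound 4 is expected to show a 2.1-fold higher number from compound 3 to compound 4 (0.33 log units; beyond the scatter) because the same change gave a 2.2-fold higher number from compound 1 to compound 2 (0.35 log units; beyond the scatter) on the other core, though that rests on a single example. Compound 4 is therefore estimated at 15000 nM, most likely between 7000 nM and 35000 nM.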

Compound 4, concentration lethal to 50% of the cells: > 100000 nM
Compound 4 ended at the assay's limit; the forecaster's own chance of this, stated with the estimate: 5%; at least 6.6-fold (0.82 log units) between middle value and limit.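

In this assay compound 4 gives > 100000 nM, which is a limit of the assay and not a number. On the core of compound 3, amino in place of hydrogen on an aromatic carbon gave an at least 14-fold higher number from compound 3 to compound 4 (1.14 log units; beyond the scatter); two pairs cannot show why the two cores differ or what the change would do on a further core. The direction of the step carried over from one core to the other, but its size did not: the same change on two cores in this assay, a 2.2-fold higher number (0.35 log units; beyond the scatter) from compound 1 to compound 2 and an at least 14-fold higher number (1.14 log units; beyond the scatter) from compound 3 to compound 4, at least 6.3-fold (0.79 log units) apart, beyond the scatter of two such steps

The compounds shown leave open whether a different group in the same place, such as a methylamino group or a hydroxyl group, would also give steps of different size on these two cores.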